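Trifluoromethyl Added to the Phenyl Ring of Compound 2

The source may report more compounds than this note shows. Statements on the series, on what has been measured and on what is new or still open speak of the compounds shown alone.

Measured so far:
compound 1, `COc1cc2c(Oc3ccc(NC(=O)c4nn(-c5ccccc5)c(=O)cc4C)cc3F)ccnc2cc1OCCCN1CCCCC1`, 1370 nM
compound 2, `COc1cc2c(Oc3ccc(NC(=O)c4nn(-c5ccccc5)c(=O)cc4C)cc3F)ccnc2cc1OCCCN1CCN(C)CC1`, 2120 nM

Two compounds share one core and differ only at the end of the saturated chain. In a functional assay on U-87MG ATCC cells (Homo sapiens) for inhibition, read by MTT assay, with a stated time of 72 h (on this read-out higher numbers stand for weaker inhibition and lower numbers for stronger inhibition), compound 1 gives 1370 nM. In this assay compound 2 gives 2120 nM. For the measured compounds named here, the step of a 1.5-fold higher number from compound 1 to compound 2 (0.19 log units; within the scatter), so the two values cannot be told apart; compound 2 has the higher of the two numbers, with compound 1 as its only neighbour.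

Compound 3, `COc1cc2c(Oc3ccc(NC(=O)c4nn(-c5ccccc5C(F)(F)F)c(=O)cc4C)cc3F)ccnc2cc1OCCCN1CCN(C)CC1`, keeps the chain of compound 2 and changes the phenyl ring instead: trifluoromethyl in place of hydrogen on an aromatic carbon. Going by the values given here, no measured step touches this ring, since the one measured step, a 1.5-fold higher number from compound 1 to compound 2 (0.19 log units; within the scatter), lies at the far end of the molecule. There is therefore no measured basis for expecting a shift beyond the scatter in this assay in either direction.

Compound 3 is expected to give about 2100 nM in this assay, a range of 800 nM to 5500 nM, that is an estimated step of a 1.0-fold lower number from compound 2 to compound 3 (0.00 log units; within the scatter).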

Compound 3, half-maximal inhibitory concentration: 1170 nM
Compound 3: middle estimate off by 1.8-fold (0.25 log units), on the high side; the range from low to high includes it.
By their numbers in this assay, from the lowest: compounds 3, 1 and 2 (each within the scatter of the next).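

In this assay, trifluoromethyl in place of hydrogen on an aromatic carbon, ortho to a large group, gives a 1.8-fold lower number from compound 2 to compound 3 (0.26 log units; within the scatter), so this position of the phenyl ring accepts a group of four heavy atoms without a change that can be told from the scatter. For the compounds shown here, this is the first measured look at this ring, since the earlier step between compounds, a 1.5-fold higher number from compound 1 to compound 2 (0.19 log units; within the scatter), lies at the far end of the chain, and at both places the step so far stays within the scatter. Nothing measured alongside these compounds speaks to the reason for this result.

From the compounds shown here alone, what an amine or a carboxylic acid would do on the same aromatic carbon stays open, and a result for either could show whether this position responds to any group at all or only tolerates trifluoromethyl. Going by these compounds, it also stays open whether trifluoromethyl gives a similar result when combined with the piperidin-1-yl chain end of compound 1, since the two changes have so far been seen only one at a time.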